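Amine substituent variation: tert-butyl to cyclohexyl

The compounds below may be only part of what the source reports. "The series", "measured", "known", "first", "only" and "open" are said of these compounds alone.

Three measured compounds share one core and differ only in the group on a saturated chain carbon bound to an amine nitrogen. In an assay on CHO cells with 5-hydroxytryptamine receptor 1D (Homo sapiens) as the target (a higher number here means a weaker inhibitor, a lower number a stronger inhibitor), compound 1 `CN(CC1CC1)CC1(O)CCN(CCCc2c[nH]c3ccc(-n4cnnc4)cc23)CC1` gives 1.35 nM. Compound 2 `CN(CC(C)(C)C)CC1(O)CCN(CCCc2c[nH]c3ccc(-n4cnnc4)cc23)CC1` gives 1.8 nM. Compound 3 `CN(Cc1ccccc1)CC1(O)CCN(CCCc2c[nH]c3ccc(-n4cnnc4)cc23)CC1` gives 1.2 nM. Compound 2 has the highest of the three numbers, yet the steps of a 1.3-fold higher number from compound 1 to compound 2 (0.12 log units; within the scatter) and a 1.5-fold lower number from compound 2 to compound 3 (0.18 log units; within the scatter) are both within the scatter, so no order among the three can be claimed.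

Compound 4 `CN(CC1CCCCC1)CC1(O)CCN(CCCc2c[nH]c3ccc(-n4cnnc4)cc23)CC1` carries the change (cyclohexyl in place of tert-butyl on a saturated chain carbon bound to an amine nitrogen). Among the measured compounds shown here, the steps that bear on it are the three exchanges at the same place: a 1.3-fold higher number from compound 1 to compound 2 (0.12 log units; within the scatter), a 1.1-fold lower number from compound 1 to compound 3 (0.05 log units; within the scatter) and a 1.5-fold lower number from compound 2 to compound 3 (0.18 log units; within the scatter). Cyclopropyl, tert-butyl and phenyl all give numbers within the scatter of one another; cyclohexyl itself has no measured counterpart here. The expectation is therefore a step of a 1.2-fold lower number from compound 2 to compound 4 (0.08 log units; within the scatter) in this assay, that is, none beyond the scatter. Compound 4 is estimated at 1.5 nM, with a range from 0.7 nM to 3.2 nM.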

Compound 4, half-maximal inhibitory concentration: 1.2 nM
For compound 4 the middle estimate is 1.3-fold (0.10 log units) above the measured one; low and high end bracket the measured number.
By their numbers in this assay, from the lowest: compounds 3, 4, 1 and 2 (each within the scatter of the next).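

In this assay, cyclohexyl adds a fourth group at this place on a saturated chain carbon bound to an amine nitrogen, and none of its steps leaves the scatter (for tert-butyl a 1.5-fold lower number from compound 2 to compound 4 (0.18 log units; within the scatter); for phenyl no change at the digits printed from compound 3 to compound 4 (within the scatter); for cyclopropyl a 1.1-fold lower number from compound 1 to compound 4 (0.05 log units; within the scatter)). The phenyl exchange also shows that a non-aromatic six-membered ring of carbon only reads the same here as the phenyl ring, so the four compounds cannot be ordered by this group. No supporting measurement speaks to the reason for this flat reading.

On these data alone, all four groups contain carbon only, so the effect of a carboxylic acid, a primary amine or a hydroxyl at this place remains open. Also open is whether a longer chain in place of cyclohexyl would keep the number within the scatter of these compounds.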